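The source may hold more compounds than are shown below. What is called first, only, known or untested is meant among the compounds shown, and "the series" means these compounds.

Working notes on the series built on the shared core seen in compound 1 `COc1ccccc1C(=O)Nc1[nH]nc(-c2ccccn2)c1C1CC1`, compound 2 `O=C(Nc1[nH]nc(-c2ccccn2)c1C1CC1)c1c(Cl)cccc1Cl` and compound 3 `O=C(Nc1cc(-c2ccccn2)n[nH]1)N1CCC(Oc2ccccn2)CC1`, all read in an ADME assay on liver (Mesocricetus auratus) for metabolic stability, using microsomes; on this read-out higher numbers stand for fast clearance and lower numbers for slow clearance. Compound 1 returns only a limit of the assay, > 100 mL.min-1.g-1. Compound 2 likewise returns a limit, > 100 mL.min-1.g-1. Among the measured compounds shown here, the one measured step, a step that the two limits leave unreadable from compound 1 to compound 2, therefore cannot be sized. For the measured compounds named here, compound 3 gives 67.3 mL.min-1.g-1, the only true number in the set. The remaining two entries are described by the limit of > 100 mL.min-1.g-1 in this assay, at which 2 of the 3 values shown sit.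

Going by the values given here, compound 4 `N#Cc1ccc(C2CCN(C(=O)Nc3cc(-c4ccccn4)n[nH]3)CC2)cc1` is not yet measured. 4-cyanophenyl in place of (pyridin-2-yl)oxy on a saturated ring carbon The change sits on the saturated ring carbon that in compound 3 carries the (pyridin-2-yl)oxy group; no measured step touches this position, and the only measured step is unreadable, so nothing in the data bears on its size. With no evidence pointing either way, the expected step of a 1.0-fold higher number from compound 3 to compound 4 (0.02 log units; within the scatter) is estimated to stay within the scatter. Compound 4 is therefore expected to give 70 mL.min-1.g-1, within 30 mL.min-1.g-1 to 150 mL.min-1.g-1, in this assay.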

Compound 4, intrinsic clearance in microsomes: 80.8 mL.min-1.g-1
Estimate against measurement, compound 4: 1.2-fold (0.06 log units) below, within the range that was stated.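

In this assay, the saturated ring carbon of the six-membered ring with 1 nitrogen now has its first readable step, a 1.2-fold higher number from compound 3 to compound 4 (0.08 log units; within the scatter), for 4-cyanophenyl in place of (pyridin-2-yl)oxy. On this read-out the two groups cannot be told apart at this place, although one carries a nitrile and an all-carbon aromatic ring and the other an oxygen and a ring nitrogen. The step from compound 1 to compound 2 still cannot be read, because both of those entries are limits of the assay: the limit of > 100 mL.min-1.g-1 in this assay, at which 2 of the 4 values shown sit.

On these data alone, both groups compared here are six-membered aromatic rings, so it stays open whether a non-aromatic group on that ring carbon, such as a primary amine or a carboxylic acid, would read apart from compound 3. The cause of the clearance seen in compound 3 and compound 4 also stays open.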